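The source may report more compounds than this note shows. Statements on the series, on what has been measured and on what is new or still open speak of the compounds shown alone.

Compound 1 `O=C(N/N=C/c1ccccc1O)c1cc(-c2ccc(Cl)cc2)nn1Cc1ccc(Cl)nc1` holds the lower of the two numbers recorded so far in a functional assay on A549 cells (Homo sapiens) for antiproliferative activity, read by BrdU incorporation, with a stated time of 48 h; on this read-out higher numbers stand for weaker inhibition and lower numbers for stronger inhibition; in this assay compound 1 gives 300 nM. Among the measured compounds shown here, the only other measured compound, compound 2 `CC(C)(C)c1ccc(Cn2nc(-c3ccc(Cl)cc3)cc2C(=N)NO)cc1`, differs from it in more than one place and gives 17000 nM in this assay, a gap well beyond the scatter. Compound 3 `N#Cc1ccc(/C=N/NC(=O)c2cc(-c3ccc(Cl)cc3)nn2Cc2ccc(Cl)nc2)cc1` keeps the core of compound 1 and carries a single change: 4-cyanophenyl in place of 2-hydroxyphenyl on a carbon with a double bond to nitrogen. No pair of measured compounds differing in just one place exists here, so the size of this step has no precedent among the numbers shown. A modest weakening in this assay is expected for compound 3, a step of a 2.3-fold higher number from compound 1 to compound 3 (0.37 log units; beyond the scatter) that may well remain inside the scatter. Compound 3 is accordingly estimated at 700 nM in this assay, within a range of 150 nM to 3500 nM.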

Compound 3, half-maximal inhibitory concentration: > 100000 nM
Compound 3 was reported as a limit; the forecaster's own chance of this, stated with the estimate: 5%; middle value at least 140-fold (2.15 log units) away from the limit.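

In this assay the value of compound 3 is a limit of the assay and not a number: the limit of > 100000 nM in this assay, at which 1 of the 3 values shown sits. Among the compounds shown here, putting 4-cyanophenyl in place of 2-hydroxyphenyl on a carbon with a double bond to nitrogen gives an at least 330-fold higher number from compound 1 to compound 3 (2.52 log units; beyond the scatter), the first step in this set that changes one place only. It shows that this place alone can carry the read-out from the nanomolar value of the core of compound 1 to the limit of the assay, so the aromatic ring here is not interchangeable, even though both groups count one six-membered aromatic ring of carbon only.

The single step swaps two features together, the hydroxyl and the nitrile, and the compounds shown do not tell which of them matters or whether their place on the ring does. A plain phenyl, a 4-hydroxyphenyl or a 2-aminophenyl on this carbon would separate these readings.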